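The compounds below may be only part of what the source reports. "The series", "measured", "known", "first", "only" and "open" are said of these compounds alone.

Measured so far in a functional assay on SF-268 cells (Homo sapiens) for inhibition, read by sulforhodamine B assay, with a stated time of 48 h, tested at 10 uM; on this read-out higher numbers stand for more inhibition of growth at the one concentration tested and lower numbers for less inhibition of growth:
compound 1 `C/C(=N\O)c1ccc(NC(=O)Cn2nc(-c3ccc(Cl)cc3)nc2N)cc1` gives 10.5%
compound 2 `COc1ccc(-c2nc3sc(-c4ccccc4)cn3n2)cc1` gives 28%
compound 3 `Clc1ccc(-c2cn3nc(-c4ccccc4)nc3s2)cc1` gives 20%

Compound 3 stands at 20% in this assay and lies within the usual scatter of compound 2 and of compound 1, its nearest and furthest neighbours on these numbers. The next compound to be tested is compound 4 `COc1ccc(-c2nc3sc(-c4ccc(Cl)cc4)cn3n2)cc1` and it differs from compound 3 in one place (methoxy in place of hydrogen on an aromatic carbon): methoxy in place of hydrogen on an aromatic carbon, para to a large group. Within the data shown here, no measured pair here shows this change on its own, so there is no direct step to draw on. Compound 2 also carries a methoxy and gives 28% in this assay and on that basis a small upward move is expected, not beyond the scatter. The expected change is a number 5 percentage points higher from compound 3 to compound 4 (within the scatter) and it stays within the scatter. For compound 4 the estimated value is 25% with an expected range from 10% to 42% until the measurement is in.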

Compound 4, percent growth inhibition at one concentration: 34.9%
Beside the measured number, compound 4's estimate is 9.9 percentage points below it, within the range that was stated.
By their numbers in this assay, from the lowest: compounds 1, 3, 2 and 4 (each within the scatter of the next, the first and the last beyond it).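

In this assay, among these compounds, methoxy in place of hydrogen on an aromatic carbon, para to a large group, gives a number 14.9 percentage points higher from compound 3 to compound 4 (beyond the scatter), the first direct reading of this change at this position. The other new pair, with chloro in place of hydrogen on an aromatic carbon, gives a number 6.9 percentage points higher from compound 2 to compound 4 (within the scatter), so of these two single changes only the methoxy step is printed beyond the usual scatter. No evidence is at hand that bears on why the methoxy step arises.

The methoxy step rests on this one pair, so the compounds shown leave open whether it would recur on a different core or with other groups elsewhere on the molecule. They also leave open what an amine, a hydroxyl or a longer chain such as ethoxy would give at this same position.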